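A few compounds are considered here, and "the series" means these few. Any claim that something is new, unique, unknown or untested is made for them only; others in the source may bear on it.

In a functional assay on cells (Mast cell, Rattus norvegicus, strain Wistar) for activation, read by fluorescence, with a stated time of 15 min; on this read-out higher numbers stand for an effect only at larger amounts of compound and lower numbers for an effect already at smaller amounts:
- compound 1 `CCCCCCCCCCCCCCCCCC(=O)OC[C@@H](O)COP(=O)(O)O[C@@H](C)[C@H](N)C(=O)O`: 2000 nM
- compound 2 `CCCCCCCCCCCCCCCCCC(=O)OC[C@@H](O)COP(=O)(O)OC[C@H](NC)C(=O)O`: > 10000 nM

The entry for compound 2 is a limit of the assay and not a number. Compound 2 stands at the limit of > 10000 nM in this assay, at which 1 of the 2 values shown sits.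

Compound 3 `CCCCCCCCCCCCCCCCCC(=O)OC[C@@H](O)COP(=O)(O)O[C@@H]1CN[C@@H](C(=O)O)C1` carries a group of 8 heavy atoms (5 carbon, 1 nitrogen, 2 oxygen; one five-membered non-aromatic ring with 1 hetero atom) in place of a group of 7 heavy atoms (4 carbon, 1 nitrogen, 2 oxygen; no ring), on an oxygen. Going by the values given here, the five-membered non-aromatic ring has no precedent among the measured compounds.

Among the compounds with values here, one measured step bears on this place, also a swap of groups on an oxygen: an at least 5.0-fold higher number from compound 1 to compound 2 (0.69 log units; beyond the scatter). That step lies beyond the scatter, but it is a single step and gives no direction for a ring.

The expectation therefore rests on compound 2, with its limit of > 10000 nM. In this assay no change beyond the scatter is expected, and the expected step is a number no higher from compound 2 to compound 3 (the limit leaves the size open). For compound 3 the estimate is 10000 nM, with an expected range of 3000 nM to 30000 nM.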

Compound 3, half-maximal effective concentration: > 10000 nM
Compound 3: only a limit was reported; the forecaster's own chance of this, stated with the estimate: 75%; the middle value lies on the limit itself.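

In this assay, the group with one five-membered non-aromatic ring with 1 hetero atom, on an oxygen whose other neighbours are phosphorus, gives an at least 5.0-fold higher number from compound 1 to compound 3 (0.69 log units; beyond the scatter). A ring group at this place thus joins the open-chain group of compound 2 in falling short of compound 1, which is now the only one of the three with a readable number. The step from compound 2 to compound 3 cannot be read, because both entries are limits of the assay and not numbers: the limit of > 10000 nM in this assay, at which 2 of the 3 values shown sit.

As far as these compounds go, how far compound 2 and compound 3 actually lie from each other stays open, as does how much of the loss belongs to the ring itself. Also open, from the compounds shown here alone, is what a longer chain on the ester, or an amide in place of the carboxylic acid, would do with the group of compound 1 kept.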